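From Isopropylamino to Methyl on a Carbonyl Carbon

This account rests on a few compounds, and the source may have more. Where it says the series, first, only, none or still open, it means among the compounds named here.

In a functional assay on U-373MG ATCC cells (Homo sapiens) for inhibition, read by MTT assay, with a stated time of 72 h (a higher number here means a weaker inhibitor, a lower number a stronger inhibitor), compound 1 `CC1(C)CC(NC(=O)NCc2ccccc2)c2cc(Cl)ccc2O1` gives 66000 nM and compound 2 `CC(C)NC(=O)NC1CC(C)(C)Oc2ccc(Cl)cc21` gives 62000 nM. Among the measured compounds shown here, both are the only numbers so far, and they cannot be ranked: the measured step, a 1.1-fold lower number from compound 1 to compound 2 (0.03 log units; within the scatter), put isopropyl in place of benzyl on an amide-type nitrogen. Compound 2 therefore stands level with compound 1.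

Compound 3 `CC(=O)NC1CC(C)(C)Oc2ccc(Cl)cc21` goes further, with methyl in place of isopropylamino on a carbonyl carbon. For the measured compounds named here, the whole isopropylamino group leaves, not just its isopropyl, and no measured compound lacks that nitrogen. Going by the values given here, the single measured step is thus only a partial guide. It shows that exchanging the group on that nitrogen moved the number no further than a 1.1-fold lower number from compound 1 to compound 2 (0.03 log units; within the scatter), so a large change is not expected, although the data cannot exclude one. The expected step is a 1.3-fold higher number from compound 2 to compound 3 (0.11 log units; within the scatter), small and leaning toward a higher number, meaning a slightly weaker inhibitor. For compound 3 the estimated value is 80000 nM, with an expected range of 35000 nM to 180000 nM.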

Compound 3, half-maximal inhibitory concentration: > 100000 nM
Compound 3 ended at the assay's limit; the forecaster's own chance of this, stated with the estimate: 30%; at least 1.2-fold (0.09 log units) between middle value and limit.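

In this assay compound 3 gives > 100000 nM, which is a limit of the assay and not a number. The earlier pair changed only the group on the nitrogen and both gave readable values, whereas this change removes that nitrogen from the carbonyl carbon altogether: replacing isopropylamino with methyl gives an at least 1.6-fold higher number from compound 2 to compound 3 (0.20 log units; that floor lies within the scatter), and replacing benzylamino with methyl gives an at least 1.5-fold higher number from compound 1 to compound 3 (0.18 log units; that floor lies within the scatter). As far as these compounds go, both floors lie within the scatter, so the result allows a real loss of inhibition without proving one, and the true size of both steps stays unknown because compound 3 reads only as a limit: the limit of > 100000 nM in this assay, at which 1 of the 3 values shown sits.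

The compounds shown cannot separate the loss of the nitrogen from the loss of the isopropyl or benzyl group carried on it, since both leave together in these steps. A plain amino group on the carbonyl carbon would keep the nitrogen without either group, and a longer chain such as propyl in place of methyl would restore the carbon atoms without the nitrogen, so each would address one half of that question.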